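Swapping phenyl for methyl on the open-chain core

The source may report more compounds than this note shows. Statements on the series, on what has been measured and on what is new or still open speak of the compounds shown alone.

Compound 1 `CCOc1ccc(-n2nnc3n[nH]c(NC)c3c2=O)cc1` and compound 2 `CCOc1ccc(-n2nnc3n[nH]c(Nc4ccccc4)c3c2=O)cc1` share a fused core and differ at one spot. In a functional assay on PANC-1 cells (Homo sapiens) for cytotoxicity, read by resazurin assay, with a stated time of 48 h (a lower number here means a stronger inhibitor, a higher number a weaker inhibitor), compound 1 gives 9920 nM and compound 2 gives 13100 nM; the change between them is methyl in place of phenyl on a nitrogen on an aromatic ring and it made a 1.3-fold lower number from compound 2 to compound 1 (0.12 log units; within the scatter). Compound 3 `CCOc1ccc(NC(=O)/C(C#N)=C(\Nc2ccccc2)SC)cc1` carries an open-chain core instead; the difference between the two cores is not broken down here. In this assay compound 3 gives 49300 nM, the highest of the three numbers. Compound 4 `CCOc1ccc(NC(=O)/C(C#N)=C(\NC)SC)cc1` has not been measured. It differs from compound 3 by methyl in place of phenyl on an amine nitrogen. This is the same kind of change as from compound 2 to compound 1, but the place differs: here the nitrogen is an amine nitrogen whose other neighbours are a double-bonded chain carbon, whereas there it was a nitrogen on an aromatic ring whose other neighbours are aromatic carbon. Because a 1.3-fold lower number from compound 2 to compound 1 (0.12 log units; within the scatter) was small, the step for compound 4 in this assay is expected to be small too, a 1.2-fold lower number from compound 3 to compound 4 (0.09 log units; within the scatter). Compound 4 is therefore estimated at 40000 nM, with a likely range from 15000 nM to 100000 nM.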

Compound 4, half-maximal inhibitory concentration: 26400 nM
The estimate for compound 4 lay 1.5-fold (0.18 log units) above the measured number; measured number inside the range.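

In this assay, putting methyl in place of phenyl on the amine nitrogen of the open-chain core gives a 1.9-fold lower number from compound 3 to compound 4 (0.27 log units; within the scatter). Set beside the same swap on the fused core, the two steps agree as far as these data can tell: the same change on two cores in this assay, a 1.3-fold lower number (0.12 log units; within the scatter) from compound 2 to compound 1 and a 1.9-fold lower number (0.27 log units; within the scatter) from compound 3 to compound 4, 1.4-fold (0.15 log units) apart, within the scatter of two such steps. So for these two pairs, anilino to methylamino leaves the number within the usual scatter on both cores, but this does not show that either step is a real effect, and two pairs cannot make a rule for the whole series.

On these data alone, only phenyl and methyl appear on this nitrogen, so it remains open what an ethyl group, a longer chain or a chain ending in a carboxylic acid would do there on either core. As far as these compounds go, it also remains open whether a change large enough to stand clear of the scatter would carry from one core to the other in the same way.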